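This account rests on a few compounds, and the source may have more. Where it says the series, first, only, none or still open, it means among the compounds named here.

Working notes on the series.

Three compounds have numbers in a functional assay on Huh-7 cells (Homo sapiens) for antiproliferative activity, read by CCK-8 assay, with a stated time of 72 h; on this read-out higher numbers stand for weaker inhibition of growth and lower numbers for stronger inhibition of growth. Compound 1 `CC[C@@H]1C(=O)N(C)c2cnc(Nc3ccc(S(=O)(=O)NC4CCCC4)cc3)nc2N1C1CCCC1` gives 389 nM and stands lowest of the three. Compound 2 `CCC1C(=O)N(C)c2cnc(-n3ccc4cc(C(=O)NCC(C)C)ccc43)nc2N1c1ccn(C)n1` gives 5070 nM, and compound 3 `CCC1C(=O)N(C)c2cnc(Nc3ccc(S(=O)(=O)NC)cc3)nc2N1c1ccn(C)n1` gives 11900 nM; both of these numbers lie beyond the scatter from compound 1, so compound 1 is the most potent of the measured set. Compounds 2 and 3 share a different substituent on the ring nitrogen of the core and differ from compound 1 in more than one place, so no single-change step can be read between any pair of measured compounds.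

The next compound to be measured is compound 4 `CC[C@@H]1C(=O)N(C)c2cnc(Nc3ccc(S(=O)(=O)NCCCO)cc3)nc2N1C1CCCC1`. It differs from compound 1 in one place: 3-hydroxypropyl in place of cyclopentyl on a sulfonamide nitrogen. Among the measured compounds shown here, no measured pair isolates this change, so the expectation rests on compound 1 alone as the parent and on the absence of any comparable step in the data. A modest weakening is expected, of a size that may or may not exceed the scatter, with the step from compound 1 to compound 4 estimated at a 1.9-fold higher number from compound 1 to compound 4 (0.29 log units; within the scatter). Compound 4 is therefore expected to give about 750 nM in this assay, within a range of 250 nM to 2500 nM.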

Compound 4, concentration for 50% growth inhibition: 262 nM
Beside the measured number, compound 4's estimate is 2.9-fold (0.46 log units) above it, within the range that was stated.
By their numbers in this assay, from the lowest: compounds 4 and 1 (each within the scatter of the next); then compound 2; then compound 3.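

Among the compounds shown here, the first single-change step sits on the sulfonamide nitrogen: in this assay, 3-hydroxypropyl in place of cyclopentyl gives a 1.5-fold lower number from compound 1 to compound 4 (0.17 log units; within the scatter), so the two groups cannot be told apart at this position. For the compounds shown here, on the background of compound 1, the five-membered ring of carbon only can therefore give way to an open chain carrying a hydroxyl group without a change that can be read in this measurement, a result the earlier compounds could not show because none of them formed a single-change pair. Nothing available bears on why the two groups read alike.

On these data alone, it remains open whether the hydroxyl group contributes anything of its own, which a plain propyl group on the same nitrogen would separate, and whether a longer chain, a chain ending in an amine or one ending in a carboxylic acid would stay level with compound 1. As far as these compounds go, it is also open whether the same exchange would read alike with another substituent on the ring nitrogen of the core, since compound 3 differs from compound 1 in more than one place and cannot settle this.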